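The source may hold more compounds than are shown below. What is called first, only, known or untested is meant among the compounds shown, and "the series" means these compounds.

In an ADME assay on Huh-7 cells (Homo sapiens) for cytotoxicity (on this read-out higher numbers stand for lower toxicity in this test and lower numbers for higher toxicity in this test), compound 3 `COc1ccc(-c2nn(-c3ccc(F)cc3F)cc2CNCCN2CCN(C)CC2)cc1` gives > 20000 nM, which is a limit of the assay and not a number. In this assay compound 1 `Cc1ccccc1-c1nn(-c2ccc(F)cc2F)cc1CNCCN1CCN(C)CC1` gives > 20000 nM, likewise a limit. Compound 2 `Cc1ccc(-c2nn(-c3ccc(F)cc3F)cc2CNCCN2CCN(C)CC2)cc1` gives > 20000 nM in this assay, again a limit. Compound 4 `CN1CCN(CCNCc2cn(-c3ccc(F)cc3F)nc2-c2cccc(Cl)c2)CC1` has not been measured yet and differs from compound 3 by 3-chlorophenyl in place of 4-methoxyphenyl on an aromatic carbon. The measured steps at this position, a step that the two limits leave unreadable from compound 1 to compound 2, a step that the two limits leave unreadable from compound 1 to compound 3 and a step that the two limits leave unreadable from compound 2 to compound 3, have no readable size because of the limit of > 20000 nM in this assay, at which 3 of the 3 values shown sit. No step beyond the scatter can therefore be foreseen. Compound 4 is expected to remain at that limit, with an estimate of 30000 nM and a range from 15000 nM to 60000 nM. The step from compound 3 to compound 4 is thus expected to be a step that the limit leaves unreadable from compound 3 to compound 4.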

Compound 4, half-maximal cytotoxic concentration: 15000 nM
Estimate against measurement, compound 4: 2.0-fold (0.30 log units) above, and the stated range covers the measured number.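

In this assay compound 4 is the only compound shown that gives a number and not a limit, so 3-chlorophenyl at this position yields the only readable steps: an at least 1.3-fold lower number from compound 3 to compound 4 (0.12 log units; that floor lies within the scatter) and an at least 1.3-fold lower number from compound 2 to compound 4 (0.12 log units; that floor lies within the scatter) and an at least 1.3-fold lower number from compound 1 to compound 4 (0.12 log units; that floor lies within the scatter) all have floors within the scatter. They therefore show no change beyond it. The reading of this position still rests largely on a limit: the limit of > 20000 nM in this assay, at which 3 of the 4 values shown sit.

The compounds shown leave open whether 4-chlorophenyl would also give a number or stay at the limit. They also leave open how an amine or a carboxylic acid on this phenyl ring would read.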